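Solubility at one chain position: methylamino to pyrrolidinyl

The source may report more compounds than this note shows. Statements on the series, on what has been measured and on what is new or still open speak of the compounds shown alone.

Measured so far in a physicochemical assay for solubility, at pH 7.4; a lower number here means a less soluble compound, a higher number a more soluble compound
- compound 1 `COCc1nc(Nc2ccc(C(F)(F)F)cc2)c2ccc(-c3ncccc3C(F)(F)F)cc2n1` gives 0.2 ug/mL
- compound 2 `CNCc1nc(Nc2ccc(C(F)(F)F)cc2)c2ccc(-c3ncccc3C(F)(F)F)cc2n1` gives 10 ug/mL

Compound 2 stands higher of the two. In compound 3 `FC(F)(F)c1ccc(Nc2nc(CN3CCCC3)nc3cc(-c4ncccc4C(F)(F)F)ccc23)cc1` pyrrolidin-1-yl takes the place of methylamino on a saturated chain carbon bound to an aromatic carbon (pyrrolidin-1-yl in place of methylamino on a saturated chain carbon bound to an aromatic carbon). For the measured compounds named here, the one measured step sits at that same carbon, with methylamino in place of methoxy, and was large (a 50-fold higher number from compound 1 to compound 2 (1.70 log units; beyond the scatter)). That step involves no pyrrolidin-1-yl group and gives no direction here. No step beyond the scatter is expected in this assay for this change. The estimated step is small (a 1.3-fold lower number from compound 2 to compound 3 (0.10 log units; within the scatter)). Compound 3 is expected at 8 ug/mL (estimated range 2 ug/mL to 30 ug/mL).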

Compound 3, solubility: 25 ug/mL
Compound 3: the middle estimate sits 3.1-fold (0.49 log units) below what was measured; the measured number falls inside the stated range.
By their numbers in this assay, from the lowest: compound 1; then compound 2; then compound 3.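

In this assay, pyrrolidin-1-yl in place of methylamino on this saturated chain carbon gives a 2.5-fold higher number from compound 2 to compound 3 (0.40 log units; beyond the scatter) and so extends the gain, reaching a 130-fold higher number from compound 1 to compound 3 (2.10 log units; beyond the scatter) overall. The highest number therefore belongs to a group with 0 hydrogen-bond donors, so among these compounds a high number does not require the hydrogen-bond donor of methylamino. Nothing measured here explains the change. Still open, from the compounds shown here alone, is how a six-membered ring amine such as piperidin-1-yl or morpholin-4-yl would fare on this carbon. A carboxylic acid there is equally untested by these compounds.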